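The source may hold more compounds than are shown below. What is called first, only, known or untested is meant among the compounds shown, and "the series" means these compounds.

Compound 2 `O=C(/C=C\Nc1ccc(Cl)cc1)c1nc(-c2ccc(C(F)(F)F)cc2)n2ccccc12` is the only one of the four with a full number. In a functional assay on MDA-MB-231 cells (Homo sapiens) for cytotoxicity, read by MTT assay, with a stated time of 48 h (on this read-out lower numbers stand for stronger inhibition and higher numbers for weaker inhibition), compound 2 gives 3840 nM. Compound 1 `COc1ccc(-c2nc(C(=O)/C=C\Nc3ccc(Cl)cc3)c3ccccn23)cc1` differs from it by methoxy in place of trifluoromethyl on an aromatic carbon. Compound 1 reaches only a limit of the assay, > 30000 nM. The step is an at least 7.8-fold higher number from compound 2 to compound 1 (0.89 log units; beyond the scatter). Compound 3 `O=C(/C=C\Nc1ccc(F)cc1)c1nc(-c2ccc(C(F)(F)F)cc2)n2ccccc12` differs from compound 2 by fluoro in place of chloro on an aromatic carbon. Compound 3 likewise stops at a limit, > 30000 nM. That step is an at least 7.8-fold higher number from compound 2 to compound 3 (0.89 log units; beyond the scatter). Both stops are the limit of > 30000 nM in this assay, at which 2 of the 3 values shown sit. Compound 4 `COc1ccc(-c2nc(C(=O)/C=C\Nc3ccc(F)cc3)c3ccccn23)cc1` is not yet measured and differs from compound 3 by methoxy in place of trifluoromethyl on an aromatic carbon, the same change as from compound 2 to compound 1, now made on the core of compound 3. Compound 4 is expected to stay at a limit, around 60000 nM. This rests on compound 3 already giving only a limit and on the step of an at least 7.8-fold higher number from compound 2 to compound 1 (0.89 log units; beyond the scatter) made by the same change. The expected step is a step that the limit leaves unreadable from compound 3 to compound 4.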

Compound 4, half-maximal inhibitory concentration: > 30000 nM
Compound 4 gave a limit, no number; the forecaster's own chance of this, stated with the estimate: 90%; the middle value is on the limit's open side.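

Within the data shown here, compound 4 stops at a limit, so no step from compound 3 or compound 1 to compound 4 can be read: the limit of > 30000 nM in this assay, at which 3 of the 4 values shown sit. From the compounds shown here alone, how far compound 1, compound 3 and compound 4 lie past that limit stays open.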